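This account rests on a few compounds, and the source may have more. Where it says the series, first, only, none or still open, it means among the compounds named here.

Compound 1 `COc1cc(N2C(N)=C(C#N)C(c3ccc([N+](=O)[O-])cc3)C3=C2CC(C)(C)CC3=O)cc(OC)c1OC` gives 50% in a functional assay on Ehrlich cells (Mus musculus) for cytotoxicity, tested at 25 ug/mL; on this read-out higher numbers stand for a stronger effect at the one concentration tested and lower numbers for a weaker effect.
Compound 2 `COc1cc(N2C(N)=C(C#N)C(c3c(OC)ccc4ccccc34)C3=C2CC(C)(C)CC3=O)cc(OC)c1OC` gives 5% in this assay.
Compound 3 `COc1ccccc1C1C(C#N)=C(N)N(c2cc(OC)c(OC)c(OC)c2)C2=C1C(=O)CC(C)(C)C2` gives 65% in this assay.

Among these three numbers compound 1 stands second highest; the nearest step is a number 15 percentage points higher from compound 1 to compound 3 (beyond the scatter), the furthest is a number 45 percentage points lower from compound 1 to compound 2 (beyond the scatter).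

Compound 4 `COc1cc(N2C(N)=C(C#N)C(c3ccc(C)cc3)C3=C2CC(C)(C)CC3=O)cc(OC)c1OC` differs from compound 1 by methyl in place of nitro on an aromatic carbon. Among the measured compounds shown here, no measured step alters a group on the aryl ring itself; the steps that bear on it exchange the whole aryl group on the saturated ring carbon: a number 15 percentage points higher from compound 1 to compound 3 (beyond the scatter) was modest, whereas a number 45 percentage points lower from compound 1 to compound 2 (beyond the scatter) and a number 60 percentage points higher from compound 2 to compound 3 (beyond the scatter) were large. Compounds 1 and 3, each carrying a phenyl ring with one small group, sit in the middle of the range, so for compound 4 the expected step is a number 2 percentage points higher from compound 1 to compound 4 (within the scatter), hardly beyond the scatter. Compound 4 is therefore estimated at 52%, between 28% and 76%.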

Compound 4, a percentage reported as activity, at one concentration (the size of the read-out at that concentration, not a potency): 50%
The estimate for compound 4 lay 2 percentage points above the measured number; measured number inside the range.
By their numbers in this assay, from the lowest: compound 2; then compounds 1 and 4 (each within the scatter of the next); then compound 3.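

Replacing 4-nitrophenyl with 4-methylphenyl alters only the group on the aromatic carbon, and in this assay the two groups cannot be told apart (no change at the digits printed from compound 1 to compound 4 (within the scatter)). Within these compounds, the large shifts at this position therefore came with exchanges of the whole aryl group, not with this swap of nitro for methyl. Compound 4 also stands clear of the other two compounds (a number 15 percentage points lower from compound 3 to compound 4 (beyond the scatter); a number 45 percentage points higher from compound 2 to compound 4 (beyond the scatter)). No evidence is available to explain this result.

The compounds shown leave open what an amine or a carboxylic acid on this same aromatic carbon would give. They also leave open whether a longer chain there would match methyl and nitro.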